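Cytotoxicity in the diaryl ether series: amide to acid

The compounds below may be only part of what the source reports. "The series", "measured", "known", "first", "only" and "open" are said of these compounds alone.

The shared core is that of compound 1 `CCc1cc(O)c(Oc2ccccc2F)cc1F`. In an ADME assay on HepG2 cells (Homo sapiens) for cytotoxicity (a lower number here means that less compound is needed, a higher number that more compound is needed for the effect), compound 1 gives 16 ug/mL. Compound 2 `CCc1cc(O)c(Oc2ccc(C#N)cc2F)cc1F` has cyano in place of hydrogen on an aromatic carbon; in this assay compound 2 gives 16 ug/mL, and the step of no change at the digits printed from compound 1 to compound 2 (within the scatter). Compound 3 `CCc1cc(O)c(Oc2ccc(C(=O)NC)cc2F)cc1F` has methylcarbamoyl in place of hydrogen on an aromatic carbon. In this assay compound 3 gives > 32 ug/mL, which is a limit of the assay and not a number. Compound 3 thus sits at the limit of > 32 ug/mL in this assay, at which 1 of the 3 values shown sits, the only one of the three measured compounds to do so. The steps of an at least 2.0-fold higher number from compound 1 to compound 3 (0.30 log units; that floor lies within the scatter) and an at least 2.0-fold higher number from compound 2 to compound 3 (0.30 log units; that floor lies within the scatter) are accordingly bounded only from below.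

Compound 4 `CCc1cc(O)c(Oc2ccc(C(=O)O)cc2F)cc1F` is not yet measured. Its difference from compound 3 is hydroxy in place of methylamino on a carbonyl carbon. Among the measured compounds shown here, no measured step alters a substituent on a carbonyl carbon, so the two steps into compound 3 bear only indirectly: both run toward the limit, whereas the cyano step stays within the scatter. The step that the limit leaves unreadable from compound 3 to compound 4 is expected to be small, in no clear direction. Compound 4 is therefore estimated at 40 ug/mL, with a range from 20 ug/mL to 80 ug/mL, and a limit rather than a number is the more likely outcome.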

Compound 4, concentration for half-maximal effect: > 32 ug/mL
Compound 4 ended at the assay's limit (the forecaster's own chance of this, stated with the estimate: 65%); the middle value is on the limit's open side.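

In this assay compound 4 gives > 32 ug/mL, which is a limit of the assay and not a number. Carboxy in place of cyano on an aromatic carbon gives an at least 2.0-fold higher number from compound 2 to compound 4 (0.30 log units; that floor lies within the scatter), and the carboxy group set against hydrogen gives an at least 2.0-fold higher number from compound 1 to compound 4 (0.30 log units; that floor lies within the scatter), so the methylcarbamoyl group is no longer the only group at this position to reach the limit. Hydroxy in place of methylamino on the carbonyl carbon leaves the read-out at the limit, and the step between the two compounds cannot be read: the limit of > 32 ug/mL in this assay, at which 2 of the 4 values shown sit.

With both carbonyl compounds at the limit, the series gives no size for either group's effect and no order between them, and the floors of the steps from compound 1 and compound 2 still lie within the scatter. Open, as far as these compounds go, is whether a primary carboxamide, a methyl ester or an amide with a longer chain on the same carbonyl carbon would give a readable number in this assay, and whether an aminomethyl group on the aromatic carbon would stay with compound 1 and compound 2 or reach the limit.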